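The source may report more compounds than this note shows. Statements on the series, on what has been measured and on what is new or still open speak of the compounds shown alone.

The study follows a small set of compounds that share one core, which appears in compound 1 `O=C(NCCCN1CCN(CCCNc2ccnc3cc(Cl)ccc23)CC1)c1ccc(Oc2ccccc2)cc1`, compound 2 `CCCCCC(=O)NCCCN1CCN(CCCNc2ccnc3cc(Cl)ccc23)CC1`, compound 3 `NC(=O)c1ccc(C(=O)NCCCN2CCN(CCCNc3ccnc4cc(Cl)ccc34)CC2)cc1` and compound 4 `O=C(CCCc1c[nH]c2ccccc12)NCCCN1CCN(CCCNc2ccnc3cc(Cl)ccc23)CC1`. They differ only in the group attached to the carbonyl carbon of the amide. In an ADME assay on L6 cells (Rattus norvegicus) for cytotoxicity (on this read-out lower numbers stand for stronger inhibition and higher numbers for weaker inhibition), compound 1 gives 1400 nM. For compound 2 the same assay reports "not determined" (no result reported), and for compound 3 it likewise reports "not determined" (no result reported). Compound 3 therefore stands without a single number in this assay, and one further entry of the set is in the same position, so the only firm figure available comes from compound 1.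

The step from compound 3 to compound 4 is a single change: 3-(1H-indol-3-yl)propyl in place of 4-carbamoylphenyl on a carbonyl carbon. Compound 3 has no number. Going by the values given here, no measured step can be drawn to compound 4. The expectation for compound 4 rests on compound 1 alone, whose value 1400 nM sets the only reference, and no step beyond the usual scatter is assumed in either direction. On that basis compound 4 is expected to give about 2500 nM in this assay, with a plausible range from 700 nM to 9000 nM.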

Compound 4, half-maximal inhibitory concentration: 6500 nM
The estimate for compound 4 lay 2.6-fold (0.41 log units) below the measured number, within the range that was stated.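

No new step can be read from this result: compound 3 has no single number in this assay, so the change to compound 4 cannot be sized. Nothing shown here bears on why compound 4 gives its value. The compounds shown leave open how the group on the carbonyl carbon relates to the read-out in this assay.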